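A few compounds are considered here, and "the series" means these few. Any claim that something is new, unique, unknown or untested is made for them only; others in the source may bear on it.

Working notes on the series, read in a functional assay on SW480 cells (Homo sapiens) for antiproliferative activity, read by MTT assay, with a stated time of 48 h; a lower number here means a stronger inhibitor, a higher number a weaker inhibitor. Among the measured compounds shown here, compound 2 (`CCCCCCC(CCO)n1cnc2c(Cl)ncnc21`) gives 16700 nM, the only true number so far. Compound 1 (`CCCCCC(CCO)n1cnc2c(N(C)C)ncnc21`), which carries a dimethylamino group, gives > 50000 nM, which is a limit of the assay. Compound 3 (`CCCCCCC(CCO)n1cnc2c(NC)ncnc21`) gives > 50000 nM, also a limit and not a number. Compound 3 therefore has no exact position in the series, and the shared ceiling is the limit of > 50000 nM in this assay, at which 2 of the 3 values shown sit.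

The next compound is compound 4 (`CCCCCCC(CCO)n1cnc2c(N(C)C)ncnc21`). The change is methyl in place of hydrogen on a nitrogen on an aromatic ring, turning methylamino into dimethylamino.

For the measured compounds named here, the only measured step that bears on this is an at least 2.9-fold higher number from compound 2 to compound 3 (0.47 log units; beyond the scatter), for methylamino in place of chloro on an aromatic carbon. That is a different change, and its size is only a bound, so it sets no size for the added methyl. No shift beyond the scatter is expected in this assay, and a report as a limit is the likeliest outcome. This expectation rests on compound 3, whose limit is > 50000 nM. The expected step is a number no higher from compound 3 to compound 4 (the limit leaves the size open). For compound 4 the estimate is 50000 nM, with an estimated range from 20000 nM to 100000 nM.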

Compound 4, half-maximal inhibitory concentration: > 50000 nM
Compound 4: only a limit was reported; the forecaster's own chance of this, stated with the estimate: 75%; the middle value sits exactly at the limit.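

In this assay, dimethylamino in place of chloro on an aromatic carbon gives an at least 2.9-fold higher number from compound 2 to compound 4 (0.47 log units; beyond the scatter), so this replacement leaves a step beyond the scatter, as methylamino did. The added methyl on the nitrogen does not bring the reading back to a true number: compound 4 gives > 50000 nM, which is a limit of the assay. The steps from compound 3 and from compound 1 to compound 4 cannot be read, and compound 2 remains the only compound with a true number, with the rest of the series sitting at one ceiling: the limit of > 50000 nM in this assay, at which 3 of the 4 values shown sit.

From the compounds shown here alone, how far compound 1, compound 3 and compound 4 lie apart remains open, and so does whether the added methyl has any effect on activity in this assay. Also open, going by these compounds, is how an unsubstituted amino group, a methoxy group or a bromo group on the same aromatic carbon would read in this assay, which would show whether chloro is alone in giving a true number.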